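A few compounds are considered here, and "the series" means these few. Any claim that something is new, unique, unknown or untested is made for them only; others in the source may bear on it.

Measured compounds in the series:
compound 1, `CCCC/C(=C\c1cc(OCc2ccc(CCCC)cc2)ccc1OCc1ccc(C(F)(F)F)cc1)C(=O)O`, an assay on isolated protein for inhibition of Polyunsaturated fatty acid 5-lipoxygenase (Homo sapiens), read by HPLC, with a stated time of 15 min; a lower number here means a stronger inhibitor, a higher number a weaker inhibitor "not active" (no number reported)
compound 2, `CCCC/C(=C\c1cc(OCc2ccc(OCc3ccccc3)cc2)ccc1OCc1ccc(C(F)(F)F)cc1)C(=O)O`, this assay "not active" (no number reported)
compound 3, `CCCC/C(=C\c1cc(OCc2cccnc2)ccc1OCc1ccc(C(F)(F)F)cc1)C(=O)O`, this assay 2300 nM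

Compound 1 stands without a number: in this assay compound 1 is reported as "not active" (no number reported). Compound 2 stands likewise, with no number given. Among the compounds with values here, only compound 3 carries a measured value, 2300 nM, and no single step between two measured compounds is available, so nothing can be said about the size of any change among them.

Compound 4, `CCCC/C(=C\c1cc(OCc2ccc(-c3csc(C)n3)cc2)ccc1OCc1ccc(C(F)(F)F)cc1)C(=O)O`, is the next compound to be measured. Relative to compound 1 the change is 2-methyl-1,3-thiazol-4-yl in place of butyl on an aromatic carbon, para to a large group on the outer six-membered ring. Within the data shown here, with compound 1 inactive and compound 3 the only numbered compound, the direction of this step cannot be read from the data; a hetero-aromatic group at this position is, by analogy to compound 3, expected at best to bring weak measurable inhibition. Compound 4 is therefore estimated at 4000 nM, within 1000 nM to 20000 nM, with a real chance that again no number is obtained.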

Compound 4, half-maximal inhibitory concentration: 6700 nM
Compound 4: the middle estimate sits 1.7-fold (0.22 log units) below what was measured; measured number inside the range.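

In this assay the place para to a large group on the outer six-membered ring turns out to tolerate a substituent with a measurable result: with butyl, compound 1 is reported as not active, while with 2-methyl-1,3-thiazol-4-yl, compound 4 gives 6700 nM in the same test. A 4-substituted phenyl on this side therefore does not in itself rule out a number. Replacing pyridin-3-yl with 4-(2-methyl-1,3-thiazol-4-yl)phenyl still gives a 2.9-fold higher number from compound 3 to compound 4 (0.46 log units; beyond the scatter), a modest loss beyond the scatter, so pyridin-3-yl remains the better of these two groups. No measurement at hand explains either change.

Open, from the compounds shown here alone, is whether the methyl on the thiazole contributes at all. Also open, going by these compounds, is what an amine or a carboxylic acid would give at the same place on the phenyl.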